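Phenyl for dichlorophenyl on a five-membered ring

The source may report more compounds than this note shows. Statements on the series, on what has been measured and on what is new or still open speak of the compounds shown alone.

Measured so far:
Compound 1, `COc1cc(C(=O)N2CCC(CCN3CCC(C(=O)c4nc5ccccc5n4Cc4ccccn4)CC3)(c3ccc(F)cc3)C2)cc(OC)c1OC`, gives 7.66 nM in this assay.
Compound 2, `CCOCCn1c(C(=O)C2CCN(CCC3(c4ccc(Cl)c(Cl)c4)CCN(C(=O)c4cc(OC)c(OC)c(OC)c4)C3)CC2)nc2ccccc21`, gives 7.51 nM in this assay.

Both measured compounds were tested in a functional assay for antagonist activity at Substance-P receptor (Cavia porcellus); a higher number here means a weaker inhibitor, a lower number a stronger inhibitor. Compound 1 gives 7.66 nM and compound 2 gives 7.51 nM; the two numbers are within the scatter of each other, so no order can be read between them. Compound 2 thus stands at the lowest of the two numbers, with compound 1 as its nearest neighbour at practically the same value.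

The next compound, compound 3, `CCOCCn1c(C(=O)C2CCN(CCC3(c4ccccc4)CCN(C(=O)c4cc(OC)c(OC)c(OC)c4)C3)CC2)nc2ccccc21`, differs from compound 2 in one place: phenyl in place of 3,4-dichlorophenyl on a saturated ring carbon. Two chlorine atoms are taken off the aromatic ring that sits on the saturated ring carbon of the five-membered non-aromatic ring with 1 nitrogen; everything else is kept. Going by the values given here, no measured pair in this set shows what such a change does, so the expectation rests on general experience that the step is likely to weaken inhibition somewhat, in a step of the size a 4.0-fold higher number from compound 2 to compound 3 (0.60 log units; beyond the scatter) expected beyond the scatter. Compound 3 is therefore estimated at 30 nM, with a range from 8 nM to 120 nM.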

Compound 3, half-maximal inhibitory concentration: 7.59 nM
The estimate for compound 3 lay 4.0-fold (0.60 log units) above the measured number; the measured number lies below the stated range.
By their numbers in this assay, from the lowest: compounds 2, 3 and 1 (each within the scatter of the next).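

In this assay, phenyl in place of 3,4-dichlorophenyl on a saturated ring carbon of the five-membered non-aromatic ring with 1 nitrogen gives a 1.0-fold higher number from compound 2 to compound 3 (0.00 log units; within the scatter) and so the two compounds cannot be told apart by this read-out. The earlier compounds shown here offered no pair that differs only at this place, whereas this pair shows that, with the rest of the structure held fixed, the two chlorine atoms can be absent from this aromatic ring without a difference beyond the scatter. Nothing measured here accounts for this result, so what the chlorine atoms contribute at this position remains unexplained.

The compounds shown leave open whether an aromatic ring is needed on this saturated ring carbon at all, a question that a cyclohexyl group or a plain methyl group in its place would address. They also leave open whether a larger group on the aromatic ring, such as trifluoromethyl, would give a number as close to those of compound 2 and compound 3.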